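Cyclopentyl to Cyclohexyl: a Step Expected Within the Scatter

The source may report more compounds than this note shows. Statements on the series, on what has been measured and on what is new or still open speak of the compounds shown alone.

Compound 2 `CC1=C(C(=O)OC2CCCC2)C(c2ccsc2)NC(=O)N1` gives 5% in an assay on membranes from HeLa cells for displacement of a labelled ligand from adenosine receptor A3 (Homo sapiens), read by scintillation counting, with a stated time of 180 min, tested at 1 uM (on this read-out higher numbers stand for more inhibition at the one concentration tested (going by the name of the read-out) and lower numbers for less inhibition), and compound 1 `CCNC(=O)C1=C(C)NC(=O)NC1c1ccsc1` gives 1% there, the two numbers lying within the usual scatter of each other. For the measured compounds named here, the only measured step, a number 4 percentage points higher from compound 1 to compound 2 (within the scatter), exchanges the group on a carbonyl carbon and does not touch the ring examined here. Compound 3 `CC1=C(C(=O)OC2CCCCC2)C(c2ccsc2)NC(=O)N1` differs from compound 2 by cyclohexyl in place of cyclopentyl on an oxygen next to a carbonyl group. Going by the values given here, with no measured step bearing directly on this change, and the one known step small, compound 3 is expected to show no change beyond the scatter, no change at the digits printed from compound 2 to compound 3 (within the scatter). Compound 3 is therefore estimated at 5%, with a range from -5% to 15%.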

Compound 3, a percentage reported as inhibition, at one concentration (the size of the read-out at that concentration, not a potency): 1%
Compound 3: middle estimate off by 4 percentage points, on the high side; the measured number falls inside the stated range.
By their numbers in this assay, from the lowest: compounds 1, 3 and 2 (each within the scatter of the next).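

In this assay, cyclohexyl in place of cyclopentyl on an oxygen next to a carbonyl group brings a number 4 percentage points lower from compound 2 to compound 3 (within the scatter) and so shows that this change of ring size does not move the number beyond the scatter. Cyclohexyloxy in place of ethylamino on a carbonyl carbon brings no change at the digits printed from compound 1 to compound 3 (within the scatter) and thus adds a second exchange at that carbon that leaves the result within the scatter. Nothing available offers an explanation for these results.

From the compounds shown here alone, whether a benzyl group on that oxygen, or an amine or a carboxylic acid on that carbonyl carbon, would lift the number beyond the scatter remains open.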